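Swapping the aryl group on a shared anticancer core

This account rests on a few compounds, and the source may have more. Where it says the series, first, only, none or still open, it means among the compounds named here.

Measured compounds:
- compound 1, `COc1cc2c(Oc3ccc(NC(=O)c4nn(-c5ccc(Br)cc5)c(=O)c5ccccc45)cc3F)ccnc2cc1OCCCN1CCN(C)CC1`: 1370 nM
- compound 2, `COc1cc2c(Oc3ccc(NC(=O)c4nn(-c5ccccc5F)c(=O)c5ccccc45)cc3F)ccnc2cc1OCCCN1CCC(C)CC1`: 670 nM

Both compounds were tested in a functional assay on MDA-MB-231 cells (Homo sapiens) for cytotoxicity, read by MTT assay, with a stated time of 72 h; a lower number here means a stronger inhibitor, a higher number a weaker inhibitor. Compound 2 gives the lower of the two numbers; compound 1 stands beyond the scatter above it, so compound 2 counts as the stronger of the pair in this assay. The two differ in two places at once, so no single change can be credited with that gap.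

Compound 3, `COc1cc2c(Oc3ccc(NC(=O)c4nn(-c5ccc(Br)cc5)c(=O)c5ccccc45)cc3F)ccnc2cc1OCCCN1CCC(C)CC1`, has not yet been measured. It is reached from compound 2 by one change: 4-bromophenyl in place of 2-fluorophenyl on an aromatic nitrogen. Going by the values given here, the same 4-bromophenyl group is present in compound 1, but compound 1 also carries a different chain end, so the data give no clean step for this exchange.

For compound 3 a modest weakening is expected, in the direction of compound 1 because of its value 1370 nM, but the step of a 1.5-fold higher number from compound 2 to compound 3 (0.17 log units; within the scatter) is only a guess. The estimate for compound 3 is 1000 nM, within 400 nM to 2500 nM.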

Compound 3, half-maximal inhibitory concentration: 1160 nM
The estimate for compound 3 lay 1.2-fold (0.06 log units) below the measured number; the range from low to high includes it.
By their numbers in this assay, from the lowest: compounds 2, 3 and 1 (each within the scatter of the next, the first and the last beyond it).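

In this assay, putting 4-bromophenyl in place of 2-fluorophenyl on the aromatic nitrogen gives a clean single step (a 1.7-fold higher number from compound 2 to compound 3 (0.24 log units; within the scatter)), so the numbers do not tell these two aryl groups apart at this position. Compound 3 also isolates the other difference in the set, the chain end: 4-methylpiperidin-1-yl in place of 4-methylpiperazin-1-yl gives a second single step (a 1.2-fold lower number from compound 1 to compound 3 (0.07 log units; within the scatter)), so neither exchange, taken alone, can be told from the ordinary variation between repeated measurements. No separate measurement on these compounds is available to explain either number.

The aryl exchange alters both the halogen and where it sits on the ring, so 2-bromophenyl or 4-fluorophenyl would be needed to follow each of those two changes alone. On these data alone, it also remains open whether a more different group would move the number beyond the scatter, such as an unsubstituted phenyl or 4-methoxyphenyl on the aromatic nitrogen, or a morpholin-4-yl group at the end of the chain.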